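This account rests on a few compounds, and the source may have more. Where it says the series, first, only, none or still open, it means among the compounds named here.

Measured compounds:
- Compound 1 `O=C1/C(=C/c2cccnc2)CN(S(=O)(=O)c2ccc(Br)cc2)C/C1=C\c1ccccc1F`: 14600 nM
- Compound 2 `N#Cc1ccc(S(=O)(=O)N2C/C(=C\c3cccnc3)C(=O)/C(=C/c3ccccc3F)C2)cc1`: > 20000 nM
- Compound 3 `O=C1/C(=C/c2cccnc2)CN(S(=O)(=O)c2ccc(Br)cc2)C/C1=C\c1ccccc1C(F)(F)F`: 13300 nM

All three were tested in an ADME assay on L02 cells (Homo sapiens) for cytotoxicity, read by MTT assay, with a stated time of 24 h; on this read-out higher numbers stand for weaker inhibition and lower numbers for stronger inhibition. Compound 1 gives 14600 nM and compound 3 gives 13300 nM; the two sit close together, a 1.1-fold lower number from compound 1 to compound 3 (0.04 log units; within the scatter). For compound 2 the result is a limit of the assay rather than a number, > 20000 nM, which is the limit of > 20000 nM in this assay, at which 1 of the 3 values shown sits. The step from compound 1 to compound 2 is therefore known only as a floor: an at least 1.3-fold higher number from compound 1 to compound 2 (0.13 log units; that floor lies within the scatter). The change behind that step is cyano in place of bromo on an aromatic carbon.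

Compound 4 `N#Cc1ccc(S(=O)(=O)N2C/C(=C\c3cccnc3)C(=O)/C(=C/c3ccccc3C(F)(F)F)C2)cc1` has not yet been measured in this assay. Going by the values given here, it differs from compound 3 by cyano in place of bromo on an aromatic carbon, which is the same change as the one from compound 1 to compound 2, made at the same place. The two cores differ in turn by trifluoromethyl in place of fluoro on an aromatic carbon.

Among the compounds with values here, the step from compound 3 to compound 4 is expected to resemble the one from compound 1 to compound 2, an expected step of about a 2.0-fold higher number from compound 3 to compound 4 (0.29 log units; within the scatter), because compound 3 starts near compound 1, a 1.1-fold lower number from compound 1 to compound 3 (0.04 log units; within the scatter). Compound 4 is therefore estimated at about 26000 nM in this assay, within a range from 12000 nM to 60000 nM, and a limit rather than a number seems the more likely outcome.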

Compound 4, half-maximal inhibitory concentration: 13200 nM
Compound 4: the middle estimate sits 2.0-fold (0.29 log units) above what was measured; the range from low to high includes it.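

The swap of cyano for bromo on the core of compound 3 gives a 1.0-fold lower number from compound 3 to compound 4 (0.00 log units; within the scatter), and set beside the same swap on the core of compound 1 it reads as follows: the same change on two cores in this assay, an at least 1.3-fold higher number (0.13 log units; that floor lies within the scatter) from compound 1 to compound 2 and a 1.0-fold lower number (0.00 log units; within the scatter) from compound 3 to compound 4; the limit leaves it open whether they differ. The other change, trifluoromethyl in place of fluoro, gives an at least 1.5-fold lower number from compound 2 to compound 4 (0.18 log units; that floor lies within the scatter), a step that starts from a limit and is therefore known only as a floor, and beside its earlier counterpart it reads: the same change on two cores in this assay, a 1.1-fold lower number (0.04 log units; within the scatter) from compound 1 to compound 3 and an at least 1.5-fold lower number (0.18 log units; that floor lies within the scatter) from compound 2 to compound 4; the limit leaves it open whether they differ. So the series shows that on the core of compound 3 the cyano swap gives no step beyond the scatter, but it does not show whether the swap acts alike on the core of compound 1, where compound 2 gives a limit of the assay, > 20000 nM, rather than a number: the limit of > 20000 nM in this assay, at which 1 of the 4 values shown sits.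

The compounds shown leave open what number lies behind the limit of compound 2, and with it how closely the two swaps match from one core to the other. They also leave open how an amine or a carboxylic acid in place of the cyano, or a methoxy group in place of the trifluoromethyl, would read in this assay.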